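Swapping 1-ethyl-1H-pyrazol-4-yl for 3-carbamoylphenyl on a shared core

The compounds below may be only part of what the source reports. "The series", "measured", "known", "first", "only" and "open" are said of these compounds alone.

Of the compounds shown here, three that differ at a single aromatic carbon have been measured in an ADME assay (liver) for metabolic stability, with Liver microsome (Rattus norvegicus) as the target, using microsomes and NADPH, with a stated time of 30 min, tested at 1 uM; a higher number here means faster removal of the compound, a lower number slower removal. There, compound 1 (`Nc1ccc(S(=O)(=O)N2CCN(c3ncc(C(O)(C(F)(F)F)C(F)(F)F)cc3C#CC3CC3)CC2)cn1`) gives 67 mL.min-1.g-1, compound 2 (`COCC#Cc1cc(C(O)(C(F)(F)F)C(F)(F)F)cnc1N1CCN(S(=O)(=O)c2ccc(N)nc2)CC1`) gives 399 mL.min-1.g-1 and compound 3 (`CCn1cc(-c2cc(C(O)(C(F)(F)F)C(F)(F)F)cnc2N2CCN(S(=O)(=O)c3ccc(N)nc3)CC2)cn1`) gives 194 mL.min-1.g-1. Compound 3 therefore holds the second highest of the three numbers, with both gaps beyond the usual scatter.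

Compound 4 (`NC(=O)c1cccc(-c2cc(C(O)(C(F)(F)F)C(F)(F)F)cnc2N2CCN(S(=O)(=O)c3ccc(N)nc3)CC2)c1`) has 3-carbamoylphenyl in place of 1-ethyl-1H-pyrazol-4-yl on that aromatic carbon: 3-carbamoylphenyl in place of 1-ethyl-1H-pyrazol-4-yl on an aromatic carbon.

Two measured steps leave the same group and bear most directly on this change. One is a 2.1-fold lower number from compound 2 to compound 3 (0.31 log units; beyond the scatter), and the other, in the opposite direction, is a 2.9-fold higher number from compound 1 to compound 3 (0.46 log units; beyond the scatter). The largest change seen at this place is a 6.0-fold higher number from compound 1 to compound 2 (0.77 log units; beyond the scatter). All are modest, so a change of that size could occur here in either direction. Among the measured compounds shown here, no measured compound carries a 3-carbamoylphenyl group, and the data give no firm direction. With compound 3 in the middle of the three numbers, the expected step is a 1.3-fold lower number from compound 3 to compound 4 (0.11 log units; within the scatter), which is no shift beyond the scatter. Compound 4 is estimated at 150 mL.min-1.g-1, with an expected range from 60 mL.min-1.g-1 to 380 mL.min-1.g-1.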

Compound 4, intrinsic clearance in microsomes: 63 mL.min-1.g-1
The estimate for compound 4 lay 2.4-fold (0.38 log units) above the measured number, and the stated range covers the measured number.
By their numbers in this assay, from the lowest: compounds 4 and 1 (each within the scatter of the next); then compound 3; then compound 2.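

In this assay, 3-carbamoylphenyl in place of 1-ethyl-1H-pyrazol-4-yl gives a 3.1-fold lower number from compound 3 to compound 4 (0.49 log units; beyond the scatter) and so shows that having an aromatic ring on this carbon does not by itself set the number; the choice of ring and its substituent matters. Measured against the 3-methoxyprop-1-yn-1-yl group, the same ring gives a 6.3-fold lower number from compound 2 to compound 4 (0.80 log units; beyond the scatter) and now marks one end of the span seen at this place. Against the 2-cyclopropylethynyl group the result is a 1.1-fold lower number from compound 1 to compound 4 (0.03 log units; within the scatter) and thus places two quite different groups, one a triple-bonded chain and the other a substituted six-membered aromatic ring, together at the low end of these four compounds.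

An unsubstituted phenyl group or a 3-carboxyphenyl group on this carbon would help to separate the part played by the six-membered ring from that of the carbamoyl group, and the compounds shown cannot make that separation. The data shown include no measurement that explains why any of these groups gives the number it does.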